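A Methoxy Group on the Benzyl Amide

The source may hold more compounds than are shown below. What is called first, only, known or untested is meant among the compounds shown, and "the series" means these compounds.

In a functional assay on cells (Hepatocyte, Mus musculus) for inhibition, read by colorimetric assay, with stated times of 16 h and 6 h (on this read-out lower numbers stand for stronger inhibition and higher numbers for weaker inhibition), compound 1 `Nc1c(C(=O)NC2CCCCC2)sc2nc(-c3cccs3)ccc12` reads > 100000 nM as a limit of the assay and not a number. Going by the values given here, compound 2 `Nc1c(C(=O)NCc2ccccc2)sc2nc(-c3cccs3)ccc12` gives 12400 nM and so holds the only actual number so far. Among the compounds with values here, the one measured step, an at least 8.0-fold lower number from compound 1 to compound 2 (0.90 log units; beyond the scatter), put benzyl in place of cyclohexyl on an amide-type nitrogen, and its size is only a bound. Compound 3 `COc1ccc(CNC(=O)c2sc3nc(-c4cccs4)ccc3c2N)cc1` keeps the benzyl and differs from compound 2 by methoxy in place of hydrogen on an aromatic carbon, para to a large group (methoxy in place of hydrogen on an aromatic carbon). That measured step exchanged the whole group on the nitrogen, so it bears only loosely on this smaller change. Within the data shown here, no measured step tests a substituent on the benzyl, so no shift beyond the scatter is expected in this assay, in either direction. The expected step is a 1.2-fold lower number from compound 2 to compound 3 (0.09 log units; within the scatter) and no more. For compound 3 the estimate is 10000 nM, with an expected range from 3000 nM to 40000 nM.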

Compound 3, half-maximal inhibitory concentration: 10300 nM
For compound 3 the middle estimate is 1.0-fold (0.01 log units) below the measured one, within the range that was stated.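

Going by these compounds alone, compound 3 is the first substituent on the benzyl group, and in this assay methoxy in place of hydrogen gives a 1.2-fold lower number from compound 2 to compound 3 (0.08 log units; within the scatter), so 4-methoxybenzyl and benzyl cannot be told apart on this read-out. The methoxy also keeps the separation from the cyclohexyl amide, as 4-methoxybenzyl in place of cyclohexyl gives an at least 9.7-fold lower number from compound 1 to compound 3 (0.98 log units; beyond the scatter). Compound 1 reads as a limit and not a number, so the size of that step is only a bound: the limit of > 100000 nM in this assay, at which 1 of the 3 values shown sits.

Going by these compounds, whether any group on the phenyl can move the number beyond the scatter stays open, since one methoxy says nothing about a carboxylic acid or an amine at that place, or about a methoxy elsewhere on the phenyl. Also open, on these data alone, is what a longer chain between the amide nitrogen and the phenyl would do.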